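This account rests on a few compounds, and the source may have more. Where it says the series, first, only, none or still open, it means among the compounds named here.

Compound 1, with the structure `COc1cc(/C=N/N(C)c2nc3ccccc3s2)cc(OC)c1O`, gives 110% in a functional assay on cells (Mus musculus) for cytotoxicity, read by MTT assay, with a stated time of 24 h, tested at 10 uM; a higher number here means a stronger effect of the compound at the concentration tested, a lower number a weaker effect. Compound 2, with the structure `COc1cc(/C=N/N(C)c2nc3ccccc3s2)cc(OC)c1OC`, gives 7% in the same setting. The two differ by a single change, (methyl in place of hydrogen on an oxygen on an aromatic ring), and the step from the first to the second is a number 103 percentage points lower from compound 1 to compound 2 (beyond the scatter).

Compound 3, with the structure `Oc1ccc(/C=N/Nc2nc3ccccc3s2)cc1O`, gives 57% in this assay. How its core differs from the core of compound 1 is not broken down here.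

Compound 4, with the structure `COc1cc(/C=N/Nc2nc3ccccc3s2)ccc1O`, has not been measured in this assay. It differs from compound 3 by methyl in place of hydrogen on an oxygen on an aromatic ring, and the place of this change reads word for word as it does between compound 1 and compound 2, so it is the same change made for a second time among these compounds.

Within the data shown here, because the single earlier instance of this change gave a number 103 percentage points lower from compound 1 to compound 2 (beyond the scatter), compound 4 is expected to land well below compound 3. The step expected for compound 4 is a number 47 percentage points lower from compound 3 to compound 4 (beyond the scatter). Compound 4 is estimated at 10% in this assay, with a range from 0% to 35%.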

Compound 4, a percentage reported as activity, at one concentration (the size of the read-out at that concentration, not a potency): 61%
For compound 4 the middle estimate is 51 percentage points below the measured one; measured number above the stated range.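

In this assay, the second instance of methyl in place of hydrogen on an oxygen on an aromatic ring is a number 4 percentage points higher from compound 3 to compound 4 (within the scatter), so hydroxy to methoxy leaves no readable effect on the core of compound 3. The change therefore cannot be carried from one core to the other in this series with its earlier size or even its earlier direction, as setting the two instances together shows: the same change on two cores in this assay, a number 103 percentage points lower (beyond the scatter) from compound 1 to compound 2 and a number 4 percentage points higher (within the scatter) from compound 3 to compound 4, 107 percentage points apart, beyond the scatter of two such steps This does not show which of the differences between the core of compound 1 and the core of compound 3 is responsible, and two instances set no rule for any further core.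

The compounds shown carry only hydroxy or methoxy at this oxygen, which leaves open what a longer chain such as ethoxy, or an amine in place of the hydroxy, would give on either core. Also open, as far as these compounds go, is whether a third core would follow compound 1 and compound 2, follow compound 3 and compound 4, or fall somewhere else.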